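A few compounds are considered here, and "the series" means these few. Any claim that something is new, unique, unknown or untested is made for them only; others in the source may bear on it.

Measured so far:
compound 1, `ClCc1ccccc1Cn1cnc2c(Cl)nc(Cl)nc21` — 4160 nM
compound 2, `ClCc1cccc(Cn2cnc3c(Cl)nc(Cl)nc32)c1` — 6160 nM
compound 3, `Nc1nc(Cl)c2ncn(Cc3ccccc3CCl)c2n1` — 57500 nM

In a functional assay on BT-549 cells (Homo sapiens) for cytotoxicity, read by sulforhodamine B assay, with a stated time of 48 h (a lower number here means that less compound is tolerated, a higher number that more compound is tolerated), compound 1 gives 4160 nM and compound 2 gives 6160 nM; the two values lie within the scatter of each other. The difference between the two cores is not broken down here. Compound 3 carries one change relative to compound 1, (amino in place of chloro on an aromatic carbon), and in this assay compound 3 gives 57500 nM, so the step is a 14-fold higher number from compound 1 to compound 3 (1.14 log units; beyond the scatter).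

Compound 4, `Nc1nc(Cl)c2ncn(Cc3cccc(CCl)c3)c2n1`, has not yet been measured. Its relation to compound 2 is amino in place of chloro on an aromatic carbon, the same change as that from compound 1 to compound 3. Since the starting point is compound 2 at 6160 nM, the step in this assay is expected to be a 13-fold higher number from compound 2 to compound 4 (1.11 log units; beyond the scatter), resting on the step of a 14-fold higher number from compound 1 to compound 3 (1.14 log units; beyond the scatter). Compound 4 is therefore estimated at 80000 nM, most likely between 30000 nM and 200000 nM.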

Compound 4, concentration lethal to 50% of the cells: 58900 nM
Beside the measured number, compound 4's estimate is 1.4-fold (0.13 log units) above it, within the range that was stated.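

In this assay, amino in place of chloro on an aromatic carbon gives a 9.6-fold higher number from compound 2 to compound 4 (0.98 log units; beyond the scatter) and so moves the number in the same direction as on the other core. The size of the step carries over between these two cores, with no difference that can be told apart: the same change on two cores in this assay, a 14-fold higher number (1.14 log units; beyond the scatter) from compound 1 to compound 3 and a 9.6-fold higher number (0.98 log units; beyond the scatter) from compound 2 to compound 4, 1.4-fold (0.16 log units) apart, within the scatter of two such steps. This shows that the change transfers across these two cores in this one cell line, but it does not show that it would transfer to any other core or assay, or why the number rises.

The compounds shown leave open how other groups on that aromatic carbon, such as a methoxy or a dimethylamino group, would compare with amino. They also leave open whether replacing the remaining ring chloro group would produce a step of similar size.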